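Half-life notes: compound 1 and its undefined-stereo form

The compounds below may be only part of what the source reports. "The series", "measured", "known", "first", "only" and "open" are said of these compounds alone.

Measured compounds:
- Compound 1, `COC(=O)CCNC(=O)[C@@H]1OP(=O)(Oc2ccc(F)cc2)OCC1(C)C`. In an ADME assay on blood (Homo sapiens) for pharmacokinetics (on this read-out lower numbers stand for a shorter-lived compound and higher numbers for a longer-lived compound), compound 1 gives > 1 h, which is a limit of the assay and not a number.
- Compound 2, `COC(=O)CCNC(=O)[C@@H]1O[P@](=O)(OCOC(=O)c2scnc2C)OCC1(C)C`. In this assay compound 2 gives < 0.16 h, also a limit rather than a number.
- Compound 3, `CC(C)(C)C(=O)OCO[P@@]1(=O)OCC(C)(C)[C@H](C(=O)NCCC(=O)OC2CCN(Cc3ccccc3)C2)O1`. In this assay compound 3 gives 0.19 h.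

Where compound 1 stands: only a limit is known for it, sitting at the limit of > 1 h in this assay, at which 1 of the 3 values shown sits. One further value in the set is a limit as well, at the limit of < 0.16 h in this assay, at which 1 of the 3 values shown sits. No pair of these compounds differs in a single place, so no measured step is available, and compound 1 cannot be ranked against compound 2 or compound 3 by more than the signs of their limits.

The unmeasured compound 4, `COC(=O)CCNC(=O)C1OP(=O)(Oc2ccc(F)cc2)OCC1(C)C`, differs from compound 1 only in drawing: the two compounds have the same atoms and bonds; at least one stereo element is drawn with a configuration in one of them and without one in the other: 1 of 2 stereo elements differ; a stereocentre at a saturated ring carbon is drawn R in compound 1 and without a configuration in compound 4. No atom leaves and none enters. Expected size of step in this assay: none beyond the scatter, since the same atoms and bonds are present and compound 4 may contain compound 1 as one of its forms. The estimate for compound 4 is 1.5 h, within 0.7 h to 4 h, a step that the limit leaves unreadable from compound 1 to compound 4, with a sizeable chance that the assay again reports only a limit.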

Compound 4, half-life: > 1 h
Compound 4: only a limit was reported (the forecaster's own chance of this, stated with the estimate: 65%); the middle value does not contradict the limit.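

No step can be read from compound 1 to compound 4 in this assay, since both results are limits of the assay and not numbers: the limit of > 1 h in this assay, at which 2 of the 4 values shown sit. The compounds shown leave open how the half-lives of compound 1 and compound 4 compare, and whether the configuration drawn at the saturated ring carbon matters for half-life.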